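Swapping Methyl for tert-Butyl on a Melanoma Cell Inhibitor

The source may report more compounds than this note shows. Statements on the series, on what has been measured and on what is new or still open speak of the compounds shown alone.

Compound 1 `COc1cc(-c2ccnc3cc(-c4ccc(C)cc4)nn23)cc(OC)c1OC` gives the lower of the two numbers in a functional assay on B16-F0 cells (Mus musculus) for inhibition, read by CCK-8 assay, with a stated time of 48 h (a lower number here means a stronger inhibitor, a higher number a weaker inhibitor), where compound 1 gives 21 nM. Compound 2 `COc1cc(-c2ccnc3cc(-c4ccc(Cl)cc4)nn23)cc(OC)c1OC` carries chloro in place of methyl on an aromatic carbon, and in this assay compound 2 gives 4090 nM, so the step of a 190-fold higher number from compound 1 to compound 2 (2.29 log units; beyond the scatter) is large. Compound 3 `COc1ccc(-c2cc3nccc(-c4cc(OC)c(OC)c(OC)c4)n3n2)cc1[N+](=O)[O-]` reaches only a limit in this assay, > 10000 nM, not a number. Compound 4 `COc1cc(-c2ccnc3cc(-c4ccc(C(C)(C)C)cc4)nn23)cc(OC)c1OC` is not yet measured; it differs from compound 1 in this way: tert-butyl in place of methyl on an aromatic carbon. Among the compounds with values here, the one measured step at this position, a 190-fold higher number from compound 1 to compound 2 (2.29 log units; beyond the scatter), shows that changing this group can weaken inhibition sharply, so some weakening is expected for compound 4. Compound 4 is estimated at 150 nM (range 20 nM to 2000 nM), an expected step of a 7.1-fold higher number from compound 1 to compound 4 (0.85 log units; beyond the scatter).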

Compound 4, half-maximal inhibitory concentration: > 10000 nM
Compound 4 ended at the assay's limit (the forecaster's own chance of this, stated with the estimate: 10%); at least 66-fold (1.82 log units) between middle value and limit.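

In this assay, tert-butyl in place of methyl gives an at least 470-fold higher number from compound 1 to compound 4 (2.67 log units; beyond the scatter), so a second replacement of the methyl, this time by a carbon-only group, also costs most of the inhibition. Tert-butyl in place of chloro gives an at least 2.4-fold higher number from compound 2 to compound 4 (0.38 log units; beyond the scatter), which places compound 4 beyond even the weak compound 2. Going by these compounds, the value of compound 4 is a limit and not a number, so the full size of both steps stays unknown: the limit of > 10000 nM in this assay, at which 2 of the 4 values shown sit. The compounds shown leave open whether an ethyl, a methoxy or an amine at this place would keep inhibition close to that of compound 1.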